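A few compounds are considered here, and "the series" means these few. Any claim that something is new, unique, unknown or untested is made for them only; others in the source may bear on it.

Working notes on the solubility series. Among the compounds with values here, compound 1 `Cc1cc(-c2cnc(N3CCN(C)CC3)nc2-c2ccc(C)s2)on1` gives 11000 nM in a physicochemical assay for solubility, with a stated time of 24 h, at pH 3; on this read-out higher numbers stand for higher solubility and lower numbers for lower solubility; compound 3 `Cc1cc(-c2cnc(NCc3ccccn3)nc2-c2ccc(C)s2)on1` gives 1000 nM, and the one measured single-point step runs an 11-fold lower number from compound 1 to compound 3 (1.04 log units; beyond the scatter). Compound 2 `COCCNc1ncc(-c2cc(C)no2)c(C2CCN(C(C)=O)CC2)n1` gives 233000 nM and so stands highest of the three numbers, with compound 1 nearest and compound 3 furthest, both gaps beyond the scatter.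

The next compound, compound 4 `CC(=O)N1CCC(c2nc(NC(C)C)ncc2-c2cc(C)no2)CC1`, differs from compound 2 in one place: isopropyl in place of 2-methoxyethyl on a nitrogen on an aromatic ring. Within the data shown here, no measured step in this set involves the same change or the same core as compound 2, so the step from compound 1 to compound 3 bears on it only as a reminder that a single substituent swap on an aromatic ring can move this read-out by a large margin. With nothing closer to lean on, the expectation for compound 4 is a modest drop, estimated at a 1.9-fold lower number from compound 2 to compound 4 (0.29 log units; within the scatter), which may or may not clear the scatter. Compound 4 is therefore expected to give about 120000 nM, within a range of 40000 nM to 300000 nM.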

Compound 4, solubility: 224000 nM
Estimate against measurement, compound 4: 1.9-fold (0.27 log units) below; the range from low to high includes it.
By their numbers in this assay, from the lowest: compound 3; then compound 1; then compounds 4 and 2 (each within the scatter of the next).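

On a nitrogen on an aromatic ring, isopropyl in place of 2-methoxyethyl gives a 1.0-fold lower number from compound 2 to compound 4 (0.02 log units; within the scatter) in this assay, so compound 2 and compound 4 stand level and this exchange leaves the read-out where it was on this core. Within the data shown here, this differs from the only earlier step, an 11-fold lower number from compound 1 to compound 3 (1.04 log units; beyond the scatter), which is a different change, made on an aromatic carbon of another core, and it shows that not every substituent swap on this scaffold family moves the number beyond the scatter. No measurement at hand accounts for the flat step.

From the compounds shown here alone, whether a longer chain, a tertiary amine or a carboxylic acid on this nitrogen would also leave the number in place stays open. Also open, going by these compounds, is whether the same exchange would read the same on the core of compound 1.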